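This account rests on a few compounds, and the source may have more. Where it says the series, first, only, none or still open, it means among the compounds named here.

Of the compounds shown here, two that share one core have been measured so far. Compound 1 `COc1ccc2[nH]c3c(c2c1)CCNC31CCN(Cc2cc(Cl)ccc2[N+](=O)[O-])CC1` carries a 5-chloro-2-nitrophenyl group on a saturated chain carbon bound to an amine nitrogen in a ring; in an assay on FRT cells for positive allosteric modulation of Cystic fibrosis transmembrane conductance regulator variant N1303K (Homo sapiens), in the presence of a further agent that is not named here (on this read-out higher numbers stand for an effect only at larger amounts of compound and lower numbers for an effect already at smaller amounts), compound 1 gives 7100 nM. Within the data shown here, compound 2 `COc1ccc2[nH]c3c(c2c1)CCNC31CCN(Cc2ccccc2Cl)CC1`, with a 2-chlorophenyl group at that place, gives 2200 nM in this assay, the lower of the two numbers, and the change a 3.2-fold lower number from compound 1 to compound 2 (0.51 log units; beyond the scatter) is the only measured step available. Compound 3 `COc1ccc2[nH]c3c(c2c1)CCNC31CCN(Cc2cc(F)cc(F)c2)CC1` has not yet been measured. It differs from compound 2 at the same place: 3,5-difluorophenyl in place of 2-chlorophenyl on a saturated chain carbon bound to an amine nitrogen in a ring. Among the measured compounds shown here, the one measured step shows that altering what sits on this ring can shift the number modestly, but it involves neither fluorine nor the 3,5-difluorophenyl pattern, so its direction cannot simply be carried over. For compound 3 the expected step is therefore small, a 1.4-fold higher number from compound 2 to compound 3 (0.13 log units; within the scatter). In this assay compound 3 is estimated at 3000 nM, within a range of 1000 nM to 9000 nM.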

Compound 3, half-maximal effective concentration: 11100 nM
Compound 3: the middle estimate sits 3.7-fold (0.57 log units) below what was measured; measured number outside the range, above it.
By their numbers in this assay, from the lowest: compound 2; then compounds 1 and 3 (each within the scatter of the next).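

In this assay, the group on a saturated chain carbon bound to an amine nitrogen in a ring can also move the number upward: replacing 2-chlorophenyl with 3,5-difluorophenyl gives a 5.0-fold higher number from compound 2 to compound 3 (0.70 log units; beyond the scatter) and is the first change shown to do so. Replacing 5-chloro-2-nitrophenyl with 3,5-difluorophenyl gives a 1.6-fold higher number from compound 1 to compound 3 (0.19 log units; within the scatter), so these two groups cannot be told apart here, while 2-chlorophenyl differs from both by steps beyond the scatter. No measurement at hand explains why the 2-chlorophenyl group gives the lowest number. This step changes both the halogen and its pattern on the ring, so the two changes cannot be separated. From the compounds shown here alone, how a plain phenyl, a pyridine ring or a carboxylic acid would behave at this place remains open.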